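Thiophen-2-yl for 4-methylphenyl: an Expected Stability Step

The source may hold more compounds than are shown below. What is called first, only, known or untested is meant among the compounds shown, and "the series" means these compounds.

Measured so far:
compound 1 `O=c1cc(N2CCN(CC3CCCCC3)CC2)sc2c(NO)cc(C(F)(F)F)cc12`, 19.1%
compound 2 `Cc1ccc(C(=O)OC2CCC(CN3CCN(c4cc(=O)c5cc(C(F)(F)F)cc([N+](=O)[O-])c5s4)CC3)CC2)cc1`, 9.7%

In an ADME assay on cells (Hepatocyte, Homo sapiens) for metabolic stability, with a stated time of 30 min (on this read-out lower numbers stand for a less stable compound and higher numbers for a more stable compound), compound 2 gives 9.7%, and compound 1 gives 19.1%; the gap between the two lies within the scatter, so neither stands apart from the other. Compound 3 `O=C(OC1CCC(CN2CCN(c3cc(=O)c4cc(C(F)(F)F)cc([N+](=O)[O-])c4s3)CC2)CC1)c1cccs1` keeps the shared core and ester of compound 2 and differs by one change: thiophen-2-yl in place of 4-methylphenyl on a carbonyl carbon. Going by the values given here, no step between measured compounds is known, so the size of this step in this assay is an estimate; a change of this kind is expected to move the number by no more than the scatter, in no clear direction, giving an expected step of a number 2.3 percentage points higher from compound 2 to compound 3 (within the scatter). Compound 3 is therefore estimated at 12%, between 4% and 25%.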

Compound 3, percent of the compound remaining: 2.2%
For compound 3 the middle estimate is 9.8 percentage points above the measured one; the whole stated range lies above it.
By their numbers in this assay, from the lowest: compounds 3, 2 and 1 (each within the scatter of the next, the first and the last beyond it).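

Thiophen-2-yl in place of 4-methylphenyl on a carbonyl carbon is the first change that can be read at this position, and in this assay it gives a number 7.5 percentage points lower from compound 2 to compound 3 (within the scatter), so the two esters are not set apart. In this one pair, a six-membered aromatic ring of carbon only gives way to a five-membered aromatic ring with sulfur without a step beyond the scatter. Nothing available bears on a cause for this step.

From the compounds shown here alone, whether a pyridin-3-yl ring, a cyclohexyl ring or a simple methyl group on this carbonyl carbon would also stay within the scatter remains open. So does the outcome of replacing the ester with an amide.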